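From chloro to bromo in one small series

The source may report more compounds than this note shows. Statements on the series, on what has been measured and on what is new or still open speak of the compounds shown alone.

Values measured in a functional assay on MOLT-4 cells (Homo sapiens) for inhibition; a higher number here means a weaker inhibitor, a lower number a stronger inhibitor:
Compound 1 `O=C1CCCCC/C1=C\c1ccccc1`: 215000 nM
Compound 2 `O=C1CCCCC/C1=C\c1cccc(Cl)c1`: 88600 nM

Of these two compounds, compound 2 has the lower number, which makes it the stronger inhibitor of the pair, and the gap between them lies beyond the usual scatter. The next compound to be tested is compound 3 `O=C1CCCCC/C1=C\c1cccc(Br)c1`. It differs from compound 2 by a single exchange: bromo in place of chloro on an aromatic carbon. In plain words, this is bromo in place of chloro on an aromatic carbon.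

Among the measured compounds shown here, only one measured step bears on this exchange: a 2.4-fold lower number from compound 1 to compound 2 (0.39 log units; beyond the scatter). That modest step brought the chloro group in, replacing hydrogen. For the measured compounds named here, no measured pair shows what happens when chloro gives way to bromo, so the evidence is indirect. Going by the values given here, one halogen replacing another is expected to matter no more than the step from hydrogen to chloro did. In this assay, a small change is therefore expected, perhaps slightly downward and probably within the scatter. The estimated result is a 1.2-fold lower number from compound 2 to compound 3 (0.07 log units; within the scatter). Compound 3 is expected to give 75000 nM, with an estimated range of 40000 nM to 140000 nM.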

Compound 3, half-maximal inhibitory concentration: 176000 nM
Beside the measured number, compound 3's estimate is 2.3-fold (0.37 log units) below it; measured number above the stated range.
By their numbers in this assay, from the lowest: compounds 2, 3 and 1 (each within the scatter of the next, the first and the last beyond it).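

In this assay, bromo on this aromatic carbon gives an unsettled picture: exchanging chloro for bromo gives a 2.0-fold higher number from compound 2 to compound 3 (0.30 log units; within the scatter), and putting bromo in place of hydrogen gives a 1.2-fold lower number from compound 1 to compound 3 (0.09 log units; within the scatter). Compound 3 therefore cannot be told apart from either of the other two compounds, even though those two are separated by a 2.4-fold lower number from compound 1 to compound 2 (0.39 log units; beyond the scatter), so the modest advantage seen with chloro is neither shown to carry over to bromo nor shown to be lost. No measurement is available that explains how these two halogens read in this assay.

The compounds shown leave open whether a group of a different kind on this same aromatic carbon, such as a methoxy, an amine or a carboxylic acid, would move the number further than either halogen does. They also leave open how the other halogens, fluoro and iodo, would compare, which could show whether the small differences among hydrogen, chloro and bromo are part of a real trend or simply reflect the scatter of the assay.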